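The compounds below may be only part of what the source reports. "The series", "measured", "known", "first", "only" and "open" are said of these compounds alone.

In a functional assay on A549 cells (Homo sapiens) for inhibition, read by colorimetric assay and MTT assay, with a stated time of 72 h (a lower number here means a stronger inhibitor, a higher number a weaker inhibitor), compound 1 `C/C1=C\CC[C@@]2(C)O[C@@H]2[C@H]2OC(=O)[C@@H](CN3CCN(c4ccccc4)CC3)[C@@H]2C[C@H]1O` gives 17000 nM. Compound 2 `C/C1=C\CC[C@@]2(C)O[C@@H]2[C@H]2OC(=O)[C@@H](CN3CCN(c4ccccc4F)CC3)[C@@H]2C[C@H]1O` differs from it by fluoro in place of hydrogen on an aromatic carbon, and in this assay compound 2 gives 22000 nM, so the step is a 1.3-fold higher number from compound 1 to compound 2 (0.11 log units; within the scatter). Compound 3 `C[C@]12O[C@@H]1CC[C@@]1(C)O[C@@H]1[C@H]1OC(=O)[C@@H](CN3CCN(c4ccccc4)CC3)[C@@H]1C[C@H]2O` has a different core; how the two cores differ is not broken down here. In this assay compound 3 gives 48000 nM, the highest of the three numbers, and its steps to compound 2 and to compound 1 are both beyond the scatter.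

Compound 4 `C[C@]12O[C@@H]1CC[C@@]1(C)O[C@@H]1[C@H]1OC(=O)[C@@H](CN3CCN(c4ccccc4F)CC3)[C@@H]1C[C@H]2O` carries the same change on the core of compound 3: fluoro in place of hydrogen on an aromatic carbon. Because the step of a 1.3-fold higher number from compound 1 to compound 2 (0.11 log units; within the scatter) stayed within the scatter, the step of a 1.3-fold higher number from compound 3 to compound 4 (0.10 log units; within the scatter) is expected to be small as well. Compound 4 is therefore estimated at 60000 nM, with a range expected from 30000 nM to 120000 nM.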

Compound 4, half-maximal inhibitory concentration: 22000 nM
For compound 4 the middle estimate is 2.7-fold (0.44 log units) above the measured one; measured number below the stated range.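

In this assay the change from phenyl to 2-fluorophenyl on the core of compound 3 gives a 2.2-fold lower number from compound 3 to compound 4 (0.34 log units; beyond the scatter). The same change therefore does not carry over unchanged from one core to the other: the same change on two cores in this assay, a 1.3-fold higher number (0.11 log units; within the scatter) from compound 1 to compound 2 and a 2.2-fold lower number (0.34 log units; beyond the scatter) from compound 3 to compound 4, 2.8-fold (0.45 log units) apart, beyond the scatter of two such steps

This shows that, for these two matched pairs, the step seen on one core did not predict the step on the other, but it does not show what in the two cores lies behind the difference or how the change would behave on any further core. The compounds shown leave open whether a chloro or a methoxy group in the same place would also differ between the two cores. They also leave open whether an amine or a carboxylic acid on the aromatic ring would do so.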